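The compounds below may be only part of what the source reports. "The series", "measured", "known", "first", "only" and "open" are said of these compounds alone.

In an ADME assay on cells (Lymphocyte, Homo sapiens) for cytotoxicity, read by MTT assay, with a stated time of 48 h (a higher number here means a weaker inhibitor, a lower number a stronger inhibitor), three esters share one core and differ only in the aryl group on the carbonyl carbon: compound 1 (`COC(=O)/C(=C\c1ccc(OC(=O)c2ccccc2)cc1)Sc1ccnc2cc(Cl)ccc12`), compound 2 (`COC(=O)/C(=C\c1ccc(OC(=O)c2cc(OC)cc(OC)c2)cc1)Sc1ccnc2cc(Cl)ccc12`) and compound 3 (`COC(=O)/C(=C\c1ccc(OC(=O)c2c(OC)cccc2OC)cc1)Sc1ccnc2cc(Cl)ccc12`). Compound 1 gives > 100000 nM, which is a limit of the assay. Compound 3 gives > 100000 nM, which is also a limit, so it has no measured number to start from. Compound 2 gives 84100 nM. Compound 4 (`COC(=O)/C(=C\c1ccc(OC(=O)c2cc(OC)cc(OC)c2OC)cc1)Sc1ccnc2cc(Cl)ccc12`) has 2,3,5-trimethoxyphenyl in place of 2,6-dimethoxyphenyl on the same carbonyl carbon: 2,3,5-trimethoxyphenyl in place of 2,6-dimethoxyphenyl on a carbonyl carbon. The measured steps that bear on this change are an at least 1.1-fold lower number from compound 1 to compound 2 (0.07 log units; that floor lies within the scatter) and an at least 1.1-fold higher number from compound 2 to compound 3 (0.07 log units; that floor lies within the scatter). Both are only floors that lie within the scatter, so swapping the aryl group has shown no readable size so far. The step expected is therefore none beyond the scatter, with a value close to the top of the range the assay can read. The expected step is an at least 1.1-fold lower number from compound 3 to compound 4 (0.04 log units; that floor lies within the scatter). For compound 4 the estimate in this assay is 90000 nM, with an expected range of 45000 nM to 180000 nM.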

Compound 4, half-maximal inhibitory concentration: 74000 nM
Compound 4: the middle estimate sits 1.2-fold (0.09 log units) above what was measured, and the stated range covers the measured number.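

Methoxy in place of hydrogen on an aromatic carbon gives a 1.1-fold lower number from compound 2 to compound 4 (0.06 log units; within the scatter) in this assay; this is the first pair at this position in which both compounds carry a measured number, and the change moves nothing beyond the scatter. The other two steps are floors only, an at least 1.3-fold lower number from compound 3 to compound 4 (0.13 log units; that floor lies within the scatter) and an at least 1.3-fold lower number from compound 1 to compound 4 (0.13 log units; that floor lies within the scatter), so 2,3,5-trimethoxyphenyl is not shown to differ from either 2,6-dimethoxyphenyl or phenyl. The aryl groups shown all stay at the weak end of what this assay can read: the limit of > 100000 nM in this assay, at which 2 of the 4 values shown sit.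

Going by these compounds, whether an amine or a carboxylic acid on this aryl ring, or a longer chain in its place, would give a step beyond the scatter stays open. Every compound shown also carries the shared core unchanged, so what a change there would do is open too.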